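The source may report more compounds than this note shows. Statements on the series, on what has been measured and on what is new or still open speak of the compounds shown alone.

Of the compounds shown here, three sharing one core have been measured in an assay on 1321N1 cells for antagonist activity at P2Y purinoceptor 6 (Homo sapiens), read by FLIPR and calcium flux; a lower number here means a stronger inhibitor, a higher number a weaker inhibitor. Compound 1 `O=[N+]([O-])C1=Cc2ccc(Cl)cc2OC1C(F)(F)F` gives 7980 nM, compound 3 `O=[N+]([O-])C1=Cc2cc(F)cc(F)c2OC1C(F)(F)F` gives 2990 nM, and compound 2 `O=[N+]([O-])C1=Cc2cc(C#Cc3ccc(CO)cc3)ccc2OC1C(F)(F)F` gives 2000 nM. Compound 2 holds the lowest of these three numbers; its gap to compound 3 lies within the usual scatter of such measurements, while its gap to compound 1 lies beyond it. Compound 4 `O=[N+]([O-])C1=Cc2cc(C#Cc3ccc(O)cc3)ccc2OC1C(F)(F)F` differs from compound 2 by a single change: hydroxy in place of hydroxymethyl on an aromatic carbon. Among the compounds with values here, no measured pair shows this same change, so its size cannot be read from the data. A step of no change at the digits printed from compound 2 to compound 4 (within the scatter) is expected, that is, no movement beyond the scatter. Compound 4 is therefore estimated at 2000 nM, with a range from 700 nM to 6000 nM in this assay.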

Compound 4, half-maximal inhibitory concentration: 5360 nM
The estimate for compound 4 lay 2.7-fold (0.43 log units) below the measured number; the range from low to high includes it.
By their numbers in this assay, from the lowest: compounds 2, 3, 4 and 1 (each within the scatter of the next, the first and the last beyond it).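

In this assay, hydroxy in place of hydroxymethyl gives a 2.7-fold higher number from compound 2 to compound 4 (0.43 log units; beyond the scatter), so compound 4 is the weaker inhibitor. Within the data shown here, this is the only measured pair differing in one place, and it shows that this position responds to the loss of a single carbon, even though the swap leaves the hydrogen-bond donor and acceptor counts unchanged. Nothing measured here explains the shift. The compounds shown leave open how an amine, a carboxylic acid or a longer chain such as hydroxyethyl would fare at this position.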